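The compounds below may be only part of what the source reports. "The series", "measured", "known", "first", "only" and "open" are said of these compounds alone.

Measured compounds and values:

Compound 1, `ClCc1ccc(Cn2cnc3c(Cl)ncnc32)cc1`: 91200 nM
Compound 2, `ClCc1cccc(Cn2cnc3c(Cl)nc(Cl)nc32)c1`: "not determined" (no result reported)
Compound 3, `ClCc1ccccc1Cn1cnc2nc(Cl)nc(Cl)c21`: 56200 nM

Three compounds share a core carrying a chloromethylbenzyl group, and two of them have been tested in a functional assay on SK-OV-3 cells (Homo sapiens) for cytotoxicity, read by sulforhodamine B assay, with a stated time of 48 h; a lower number here means that less compound is tolerated, a higher number that more compound is tolerated. Compound 1 gives 91200 nM in this assay, the highest of the two numbers. Compound 3 gives 56200 nM, a gap to compound 1 that lies within the usual scatter, so the two cannot be placed in any order. Compound 2 has no result in this assay.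

The next compound, compound 4, `ClCc1ccc(Cn2cnc3c(Cl)nc(Cl)nc32)cc1`, has not yet been measured in this assay. It differs from compound 1 in one place: chloro in place of hydrogen on an aromatic carbon

For the measured compounds named here, no pair of measured compounds differs in exactly one place, so no step of this kind has been seen directly. Going by the values given here, the only guide is that compound 3, which also carries two chloro groups on its core, sits within the scatter of compound 1. The step of a 1.3-fold lower number from compound 1 to compound 4 (0.11 log units; within the scatter) is therefore expected to be small, probably toward a lower number, and likely not beyond the scatter. For compound 4 the expected value in this assay is 70000 nM, with a range from 30000 nM to 160000 nM.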

Compound 4, concentration lethal to 50% of the cells: 66100 nM
Estimate against measurement, compound 4: 1.1-fold (0.02 log units) above; the measured number falls inside the stated range.
By their numbers in this assay, from the lowest: compounds 3, 4 and 1 (each within the scatter of the next).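

For the compounds shown here, this is the first pair that differs in only one place, so the effect of a single change can now be read directly. In this assay, placing chloro instead of hydrogen on the aromatic carbon between two ring nitrogen atoms gives a 1.4-fold lower number from compound 1 to compound 4 (0.14 log units; within the scatter), so this one extra chlorine atom on the shared core does not separate the two compounds in this measurement, and the hydrogen at this position can be exchanged for chloro without a difference that can be distinguished from ordinary repeat variation. No measurement offered here explains this result or shows what the chloro group does at this position.

The compounds shown leave open how an amine, a methoxy group or a longer chain at this same position would read in this assay, since chloro is the only replacement for hydrogen seen here. They also leave open how a hydroxymethyl or plain methyl group would compare with the chloromethyl group on the benzyl ring.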